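Nitrate-bearing pyrazolone hydrazides in a rat paw edema test

The source may report more compounds than this note shows. Statements on the series, on what has been measured and on what is new or still open speak of the compounds shown alone.

Compound 1 `COc1ccccc1-c1cc(=O)[nH]n1-c1ccc(C(=O)NNC(=O)CO[N+](=O)[O-])cc1` carries a 2-methoxyphenyl group on its pyrazolone core, and in a functional assay on the whole organism (strain Wistar) for inhibition, with Rattus norvegicus as the target, read by paw edema, with a stated time of 1 h, at a dose of 6 mg/kg by the oral route (a higher number here means more inhibition at the dose given (going by the name of the read-out), a lower number less inhibition), compound 1 gives 55.1%. Compound 2 `O=C(CO[N+](=O)[O-])NNC(=O)c1ccc(-n2[nH]c(=O)cc2-c2ccccc2O)cc1` differs from it only by the change (hydrogen in place of methyl on an oxygen on an aromatic ring), and in this assay compound 2 gives 23%, so that a number 32.1 percentage points lower from compound 1 to compound 2 (beyond the scatter). Compound 3 `CCOC(=O)c1c(-c2ccccc2OC)n(-c2ccc(C(=O)NNC(=O)CO[N+](=O)[O-])cc2)[nH]c1=O` keeps the 2-methoxyphenyl group but its core differs from that of compound 1 by ethoxycarbonyl in place of hydrogen on an aromatic carbon; in this assay compound 3 gives 31%, and a number 24.1 percentage points lower from compound 1 to compound 3 (beyond the scatter). Compound 4 `CCOC(=O)c1c(-c2ccccc2O)n(-c2ccc(C(=O)NNC(=O)CO[N+](=O)[O-])cc2)[nH]c1=O` is the not yet measured partner of compound 3: it differs from compound 3 by hydrogen in place of methyl on an oxygen on an aromatic ring, and since the surroundings of the changed oxygen are described in the same words for both pairs, this is the same change that led from compound 1 to compound 2. Because that earlier step was a number 32.1 percentage points lower from compound 1 to compound 2 (beyond the scatter), a downward step is expected here too, though starting from a lower number it is expected to be somewhat smaller: a number 19 percentage points lower from compound 3 to compound 4 (beyond the scatter). For compound 4 the estimated result in this assay is 12%, with a range from 2% to 28%.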

Compound 4, a percentage reported as inhibition, in the whole organism at one dose (the size of the read-out at that dose, not a potency): 27.8%
Compound 4: middle estimate off by 15.8 percentage points, on the low side, within the range that was stated.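

In this assay, the change from 2-methoxyphenyl to 2-hydroxyphenyl gives a number 3.2 percentage points lower from compound 3 to compound 4 (within the scatter), so the large drop seen on the core of compound 1 does not carry over to the core that bears ethoxycarbonyl: the same change on two cores in this assay, a number 32.1 percentage points lower (beyond the scatter) from compound 1 to compound 2 and a number 3.2 percentage points lower (within the scatter) from compound 3 to compound 4, 28.9 percentage points apart, beyond the scatter of two such steps

Read the other way round, with the hydroxy group already present, adding ethoxycarbonyl gives a number 4.8 percentage points higher from compound 2 to compound 4 (within the scatter), unlike the drop it brought with the methoxy group present: the same change on two cores in this assay, a number 24.1 percentage points lower (beyond the scatter) from compound 1 to compound 3 and a number 4.8 percentage points higher (within the scatter) from compound 2 to compound 4, 28.9 percentage points apart, beyond the scatter of two such steps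

Both readings rest on the same set of compounds, so they form one observation that the two changes do not simply add up here; this does not show why, nor how the methoxy to hydroxy change would behave on any other core.

The compounds shown leave open whether a longer chain on that oxygen, such as ethyl, would follow compound 1 or compound 2. They also leave open how a carboxylic acid or an amide in place of ethoxycarbonyl would alter the picture.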